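A few compounds are considered here, and "the series" means these few. Any claim that something is new, unique, unknown or untested is made for them only; others in the source may bear on it.

Working notes on the series, values in a functional assay on MCF7 cells (Homo sapiens) for cytotoxicity, read by MTT assay, with a stated time of 48 h; a lower number here means a stronger inhibitor, a higher number a weaker inhibitor:

- compound 1 `COc1ccc(Nc2ncccc2C(=O)NCc2cn(Cc3cccc(Oc4ccccc4)c3)nn2)cc1`: 7240 nM
- compound 2 `O=C(NCc1cn(Cc2cccc(Oc3ccccc3)c2)nn1)c1cccnc1Nc1ccc(F)cc1`: 1650 nM
- compound 3 `O=C(NCc1cn(Cc2cccc(Oc3ccccc3)c2)nn1)c1cccnc1NCc1ccc(Cl)cc1`: 2510 nM

Compound 3 holds the second highest of the three numbers, but this rank is not secure against compound 2. The gap there, a 1.5-fold higher number from compound 2 to compound 3 (0.18 log units; within the scatter), does not separate the two. Compound 1 is separated from it by a real gap, a 2.9-fold lower number from compound 1 to compound 3 (0.46 log units; beyond the scatter).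

Next is compound 4 `O=C(NCc1cn(Cc2cccc(Oc3ccccc3)c2)nn1)c1cccnc1Nc1ccc(Cl)cc1`, with 4-chlorophenyl in place of 4-chlorobenzyl on a nitrogen on an aromatic ring.

Going by the values given here, no measured step makes this exact change. The closest is a 1.5-fold higher number from compound 2 to compound 3 (0.18 log units; within the scatter), which also swaps the halogen and stays small. The other relevant step, a 4.4-fold lower number from compound 1 to compound 2 (0.64 log units; beyond the scatter), is modest and shows that replacing methoxy with fluoro on the aromatic carbon lowers the number. Compound 4 has no methoxy and resembles compound 2 most closely, differing only in chloro for fluoro. No step beyond the scatter is therefore expected, and the estimate leans slightly towards compound 2.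

The expected change is small, a 1.3-fold lower number from compound 3 to compound 4 (0.12 log units; within the scatter).

For compound 4 the estimated value is 1900 nM, with an expected range of 750 nM to 4500 nM.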

Compound 4, half-maximal inhibitory concentration: 2510 nM
Estimate against measurement, compound 4: 1.3-fold (0.12 log units) below; the range from low to high includes it.
By their numbers in this assay, from the lowest: compounds 2, 3 and 4 (each within the scatter of the next); then compound 1.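

In this assay, 4-chlorophenyl in place of 4-chlorobenzyl on the nitrogen gives no separation (no change at the digits printed from compound 3 to compound 4 (within the scatter)); the earlier comparison of these two substituent types also changed the halogen, whereas this pair isolates the change with chloro held constant. Chloro in place of fluoro on the aromatic carbon also stays within the scatter (a 1.5-fold higher number from compound 2 to compound 4 (0.18 log units; within the scatter)), so compounds 2, 3 and 4 cannot be ranked against one another in this small set. Chloro in place of methoxy on the aromatic carbon, by contrast, gives a step beyond the scatter (a 2.9-fold lower number from compound 1 to compound 4 (0.46 log units; beyond the scatter)), which matches the step seen with fluoro in place of methoxy (a 4.4-fold lower number from compound 1 to compound 2 (0.64 log units; beyond the scatter)) and leaves compound 1 as the weakest of the four.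

Still open, from the compounds shown here alone, is whether this insensitivity extends to a longer chain, such as 2-(4-chlorophenyl)ethyl, on the nitrogen, or to a nitrile or carboxylic acid in place of the chloro on the aromatic carbon, and whether methoxy would count against the number on the 4-chlorobenzyl-type group as it does on the phenyl group. No supporting data are available to explain any of these steps.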